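Thiosemicarbazone aryl amine: bromine for fluorine swap

The source may hold more compounds than are shown below. What is called first, only, known or untested is meant among the compounds shown, and "the series" means these compounds.

Compound 1 `NC(=S)N/N=C/c1cc2ccccc2s1`: > 100000 nM
Compound 2 `S=C(N/N=C/c1ccc2ccccc2n1)Nc1cccc(Br)c1`: 78600 nM

Compound 1 gives in a functional assay on SGC-7901 cells (Homo sapiens) for antiproliferative activity, read by sulforhodamine B assay, with a stated time of 72 h (a lower number here means a stronger inhibitor, a higher number a weaker inhibitor), only a limit of the assay, > 100000 nM. Among the compounds with values here, compound 2 gives 78600 nM in this assay, the only number so far. Of the two values shown, one sits at a limit (the limit of > 100000 nM in this assay, at which 1 of the 2 values shown sits). Compound 2 therefore stands alone as a measured number, with nothing to rank it against.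

Compound 3 `Fc1ccc(NC(=S)N/N=C/c2ccc3ccccc3n2)cc1` differs from compound 2 in one place: 4-fluorophenyl in place of 3-bromophenyl on an amide-type nitrogen. Within the data shown here, no pair of measured compounds differing in a single place exists here, so no measured step can guide the size of this change. The step from compound 2 to compound 3 is expected to be a 1.1-fold lower number from compound 2 to compound 3 (0.05 log units; within the scatter), which is within the usual scatter in this assay. Compound 3 is estimated at 70000 nM, expected to fall between 25000 nM and 200000 nM.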

Compound 3, half-maximal inhibitory concentration: 32300 nM
For compound 3 the middle estimate is 2.2-fold (0.34 log units) above the measured one; low and high end bracket the measured number.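

In this assay, the group on the amide-type nitrogen, whose other neighbour is the thiocarbonyl carbon, proves able to move the number: 4-fluorophenyl in place of 3-bromophenyl gives a 2.4-fold lower number from compound 2 to compound 3 (0.39 log units; beyond the scatter) and this is a modest step. Within the data shown here, it is the first measured step, so this position now has a size attached to it. The swap changes both the halogen and its place on the ring, and nothing shown gives a cause for the step.

On these data alone, whether the step follows the halogen or its place remains open, and 3-fluorophenyl and 4-bromophenyl would separate the two. As far as these compounds go, how an unsubstituted phenyl, a methoxyphenyl or an open alkyl chain would fare on this nitrogen also remains open.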